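Swapping a trifluoromethyl for chloro on the benzyl ring

This account rests on a few compounds, and the source may have more. Where it says the series, first, only, none or still open, it means among the compounds named here.

Three compounds share a core, each carrying a glycine-derived amide and a benzyl group on the ring nitrogen. Compound 1 `O=C(O)CNC(=O)c1c(O)c2c(n(Cc3ccc(C(F)(F)F)cc3)c1=O)CCOC2` gives 14 nM in an assay on Sf9 cells for inhibition of prolyl hydroxylase EGLN2 (Homo sapiens), read by TR-FRET, with stated times of 30 min and 2 h; on this read-out lower numbers stand for stronger inhibition and higher numbers for weaker inhibition. Compound 2 `N#Cc1ccc(Cn2c3c(c(O)c(C(=O)NCC(=O)O)c2=O)COCC3)c(F)c1` gives 6.3 nM in this assay, and the step of a 2.2-fold lower number from compound 1 to compound 2 (0.35 log units; beyond the scatter) comes from a change of the benzyl ring. Compound 3 `O=C(O)CNC(=O)c1c(O)c2c(n(Cc3ccc(C(F)(F)F)cc3)c1=O)COC2` gives 3.6 nM in this assay, the lowest of the three numbers; it sits within the scatter of compound 2 and beyond the scatter of compound 1.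

Compound 4 `O=C(O)CNC(=O)c1c(O)c2c(n(Cc3ccc(Cl)cc3)c1=O)COC2` differs from compound 3 in one place: chloro in place of trifluoromethyl on an aromatic carbon. Among the measured compounds shown here, no measured step exchanges these two groups; the only step on the benzyl ring, a 2.2-fold lower number from compound 1 to compound 2 (0.35 log units; beyond the scatter), was modest and replaced the ring substitution as a whole, so it bears on this change only loosely. The expected step of a 1.3-fold higher number from compound 3 to compound 4 (0.10 log units; within the scatter) is therefore small, in no firm direction. Compound 4 is estimated at 4.5 nM in this assay, with a range from 1.5 nM to 14 nM.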

Compound 4, half-maximal inhibitory concentration: 2.1 nM
Compound 4: the middle estimate sits 2.1-fold (0.33 log units) above what was measured, and the stated range covers the measured number.
By their numbers in this assay, from the lowest: compounds 4, 3 and 2 (each within the scatter of the next, the first and the last beyond it); then compound 1.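

This is the first step shown that exchanges a single group on the benzyl ring, since the step from compound 1 to compound 2 replaced the ring substitution as a whole. At this aromatic carbon, para to a large group, one chlorine atom stands where the four heavy atoms of trifluoromethyl stood, and this assay gives a 1.7-fold lower number from compound 3 to compound 4 (0.23 log units; within the scatter), so the two groups cannot be told apart on this read-out. No measurement shown here accounts for this result.

From the compounds shown here alone, whether this place accepts other kinds of group remains open, for example a methoxy group, an amine or a longer carbon chain. Going by these compounds, it is also open whether chloro and trifluoromethyl would match in the same way on the core of compound 1.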